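Pyrrole diester series: removal of the carbamoyl substituent

The source may report more compounds than this note shows. Statements on the series, on what has been measured and on what is new or still open speak of the compounds shown alone.

Measured compounds:
compound 1 `CCCOC(=O)c1[nH]c(COC(C)=O)c(C(=O)OC(C)(C)C)c1C`, 2700 nM
compound 2 `CCOC(=O)c1[nH]cc(C(=O)OC(C)(C)C)c1C`, 340 nM
compound 3 `CCCOC(=O)c1[nH]c(C(=O)NCC2CC2)c(C(=O)OC(C)(C)C)c1C`, 2500 nM

In an assay on CHO cells for inhibition of metabotropic glutamate receptor 1 (Rattus norvegicus) (a higher number here means a weaker inhibitor, a lower number a stronger inhibitor), compound 3 gives 2500 nM, the second highest of the three numbers; its nearest neighbour is compound 1 at 2700 nM, and the furthest is compound 2 at 340 nM, whose gap to compound 3 lies beyond the scatter.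

Compound 4 `CCCOC(=O)c1[nH]cc(C(=O)OC(C)(C)C)c1C` is not yet measured. It differs from compound 3 in one place: hydrogen in place of (cyclopropylmethyl)carbamoyl on an aromatic carbon.

Among the measured compounds shown here, only one measured step bears on this position. Going a 1.1-fold lower number from compound 1 to compound 3 (0.03 log units; within the scatter) exchanges one substituent for another at the same carbon and leaves the number essentially unchanged, so swapping between two sizeable groups there is without consequence. The change to compound 4 is different in kind, since the group is removed entirely. For the measured compounds named here, no measured step covers exactly that, but compound 2 likewise carries hydrogen where compound 3 carries the carbamoyl group; compound 2 gives the lowest number of the set at 340 nM, and its ester differs from that of compound 4 only by one carbon.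

Compound 4 is therefore expected to fall well below compound 3, with an estimated step of a 6.3-fold lower number from compound 3 to compound 4 (0.80 log units; beyond the scatter). The estimate for compound 4 in this assay is 400 nM, in the range 150 nM to 1200 nM.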

Compound 4, half-maximal inhibitory concentration: 75 nM
For compound 4 the middle estimate is 5.3-fold (0.73 log units) above the measured one; measured number below the stated range.
By their numbers in this assay, from the lowest: compound 4; then compound 2; then compounds 3 and 1 (each within the scatter of the next).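

Position notes: the aromatic carbon next to the ring nitrogen responds strongly to what it carries, a point the exchange of one sizeable group for another could not reveal, since that exchange gave only a 1.1-fold lower number from compound 1 to compound 3 (0.03 log units; within the scatter) in this assay. Removal of either group gives a large gain, with a 33-fold lower number from compound 3 to compound 4 (1.52 log units; beyond the scatter) on losing (cyclopropylmethyl)carbamoyl and a 36-fold lower number from compound 1 to compound 4 (1.56 log units; beyond the scatter) on losing acetoxymethyl, so in this pair of comparisons hydrogen is clearly preferred to both groups. The ester chain also matters with hydrogen at that carbon: a modest further step, a 4.5-fold lower number from compound 2 to compound 4 (0.66 log units; beyond the scatter), comes from methyl in place of hydrogen on the saturated chain, so compound 2 does not fully stand in for compound 4.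

Still open, going by these compounds, is whether a small group at the same carbon, such as methyl, an amine or a carboxylic acid, behaves like hydrogen or like the two larger groups. Also open, on these data alone, is whether a longer chain than propyl in the propoxycarbonyl group extends the gain, and whether that chain has the same effect when the aromatic carbon is substituted. Nothing measured here accounts for the size of these steps.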